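Replacing 4-chlorophenyl with 3-nitrophenyl: working notes

The compounds below may be only part of what the source reports. "The series", "measured", "known", "first", "only" and "open" are said of these compounds alone.

Measured in a functional assay on K562 cells (Homo sapiens) for cytotoxicity, read by MTT assay, with a stated time of 24 h; a lower number here means a stronger inhibitor, a higher number a weaker inhibitor:
compound 1 `COc1cc(/C=C2\CN(C)C/C(=C\c3ccccc3F)C2=O)cc(OC)c1`: 6320 nM
compound 2 `CN1C/C(=C\c2ccc(C(C)(C)C)cc2)C(=O)/C(=C/c2ccccc2F)C1`: 18200 nM
compound 3 `COc1cc(/C=C2\CN(C)C/C(=C\c3ccc(Cl)cc3)C2=O)cc(OC)c1`: 13300 nM

Compound 3 at 13300 nM cannot be separated from compound 2 at 18200 nM, as the two lie within the scatter of each other. Compound 4 `COc1cc(/C=C2\CN(C)C/C(=C\c3cccc([N+](=O)[O-])c3)C2=O)cc(OC)c1` carries 3-nitrophenyl in place of 4-chlorophenyl on a double-bonded chain carbon bound to a double-bonded ring carbon.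

Among the measured compounds shown here, one measured step bears on this place: a 2.1-fold higher number from compound 1 to compound 3 (0.32 log units; beyond the scatter), with 4-chlorophenyl in place of 2-fluorophenyl. For the measured compounds named here, that step is modest, and it is the only guide, since no measured compound carries 3-nitrophenyl. A step no larger than that one is therefore expected in this assay, probably none beyond the scatter, with a slight lean toward a lower number. The estimated change is a 1.3-fold lower number from compound 3 to compound 4 (0.12 log units; within the scatter). For compound 4 the expected value is 10000 nM, with an estimated range of 4000 nM to 25000 nM.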

Compound 4, half-maximal inhibitory concentration: 4420 nM
Beside the measured number, compound 4's estimate is 2.3-fold (0.35 log units) above it, within the range that was stated.
By their numbers in this assay, from the lowest: compounds 4 and 1 (each within the scatter of the next); then compounds 3 and 2 (each within the scatter of the next).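

Among the compounds shown here, at this position the aryl group can move the number in either direction: in this assay, 3-nitrophenyl gives a 3.0-fold lower number from compound 3 to compound 4 (0.48 log units; beyond the scatter), a change opposite in direction to the only earlier step here, a 2.1-fold higher number from compound 1 to compound 3 (0.32 log units; beyond the scatter). Set against 2-fluorophenyl, the same group gives a 1.4-fold lower number from compound 1 to compound 4 (0.16 log units; within the scatter), so these two groups cannot be separated, and among compounds 1, 3 and 4 it is 4-chlorophenyl that stands apart, with the higher number. No measurement available here explains this difference.

From the compounds shown here alone, whether the lower number follows the nitro group itself remains open, as does whether an amine or a carboxylic acid on that ring would keep it. Also open, going by these compounds, is whether the same order of groups would hold with a different group on the other side of the shared core.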